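The source may report more compounds than this note shows. Statements on the series, on what has been measured and on what is new or still open speak of the compounds shown alone.

Working notes on the series in a functional assay on HCT-116 cells (Homo sapiens), read by MTT assay, with a stated time of 72 h; a lower number here means a stronger inhibitor, a higher number a weaker inhibitor.

Compound 1 `CNc1ncnc2c1c(-c1ccccc1)cn2[C@@H]1O[C@H](CO)[C@@H](O)[C@H]1O` is reported only as a limit in this assay; compound 1 gives > 100000 nM. Compound 3 `CNc1ncnc2c1c(-c1cc3ccccc3o1)cn2[C@@H]1O[C@H](CO)[C@@H](O)[C@H]1O` is likewise given as a limit; in this assay compound 3 gives > 20000 nM. Compound 2 `O=c1[nH]cnc2c1c(-c1cc3ccccc3o1)cn2[C@@H]1O[C@H](CO)[C@@H](O)[C@H]1O` is also a limit; compound 2 gives > 20000 nM in this assay. The step from compound 3 to compound 1 is a step that the two limits leave unreadable from compound 3 to compound 1, the change being (phenyl in place of 1-benzofuran-2-yl on an aromatic carbon); it cannot be read because the limit of > 100000 nM in this assay, at which 1 of the 3 values shown sits, and because the limit of > 20000 nM in this assay, at which 2 of the 3 values shown sit, hold all three values at their limits.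

Compound 4 `O=c1[nH]cnc2c1c(-c1ccccc1)cn2[C@@H]1O[C@H](CO)[C@@H](O)[C@H]1O` is not yet measured. It stands to compound 2 as compound 1 stands to compound 3, the change being (phenyl in place of 1-benzofuran-2-yl on an aromatic carbon), the same change at the same place, occurring twice in all. The difference between the cores of compound 2 and compound 3 is not broken down here.

Given that every measured value sits at a limit, the step from compound 2 to compound 4 is expected to be about a step that the limit leaves unreadable from compound 2 to compound 4, with no readable measured step to anchor it. Compound 4 is expected to give around 50000 nM, between 15000 nM and 200000 nM, most likely again as a limit.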

Compound 4, half-maximal inhibitory concentration: > 20000 nM
Compound 4: no number, only a limit; the forecaster's own chance of this, stated with the estimate: 85%; the middle value is on the limit's open side.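

In this assay compound 4 gives > 20000 nM, which is a limit and not a number. For the compounds shown here, compound 2 is also reported as a limit, so the step between compound 2 and compound 4 cannot be read and no new step results. The compounds shown leave open whether exchanging 1-benzofuran-2-yl for phenyl, or the difference between the cores, changes the read-out at all.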